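This account rests on a few compounds, and the source may have more. Where it says the series, first, only, none or still open, it means among the compounds named here.

Compound 1 `CCCCCCCCS(=O)(=O)NCCCNCCCNCCCCNCCCN`: 816 nM
Compound 2 `CCCCCCCCCCS(=O)(=O)NCCCNCCCNCCCCNCCCN`: 278 nM
Compound 3 `CCCCCCCCCCCCS(=O)(=O)NCCCNCCCNCCCCNCCCN`: not yet measured

Going by the values given here, in a functional assay on HEK293 cells (Homo sapiens) for inhibition (a lower number here means a stronger inhibitor, a higher number a weaker inhibitor), compound 2 holds the lower of the two numbers so far, at 278 nM. Compound 3 carries one change from it: ethyl in place of hydrogen on a saturated chain carbon, ten or more bonds along the chain from a sulfonyl sulfur. Among the compounds with values here, the only measured step of the same kind is a 2.9-fold lower number from compound 1 to compound 2 (0.47 log units; beyond the scatter), which is modest. On that single step, a further modest move towards a lower number is expected in this assay, though one step establishes no trend and a smaller change would not surprise. The expected change is a 2.3-fold lower number from compound 2 to compound 3 (0.36 log units; beyond the scatter). The estimate for compound 3 is 120 nM, with an expected range from 45 nM to 300 nM.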

Compound 3, half-maximal inhibitory concentration: 190 nM
Compound 3: middle estimate off by 1.6-fold (0.20 log units), on the low side; the range from low to high includes it.
By their numbers in this assay, from the lowest: compounds 3 and 2 (each within the scatter of the next); then compound 1.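

In this assay, ethyl in place of hydrogen on a saturated chain carbon, ten or more bonds along the chain from a sulfonyl sulfur, gives a 1.5-fold lower number from compound 2 to compound 3 (0.17 log units; within the scatter), so this extension, unlike the earlier one, does not separate its two compounds. Over the whole series, butyl in place of hydrogen still gives a 4.3-fold lower number from compound 1 to compound 3 (0.63 log units; beyond the scatter), a modest step. No measurement shown bears on the cause. As far as these compounds go, whether a longer chain stays level with compound 2 and compound 3 or departs from them remains open. So does the effect of an amide in place of the sulfonyl group.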